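The compounds below may be only part of what the source reports. "The series", "measured", "known", "first", "only" and "open" are said of these compounds alone.

Compound 1 `O=C(CCCCC(S)CCS)Nc1ccc(F)cc1`: 6.78%
Compound 2 `O=C(CCCCC(S)CCS)Nc1ccccn1`: "not active" (no number reported)
Compound 3 `O=C(CCCCC(CCSC(=O)c1ccccc1)SC(=O)c1ccccc1)Nc1ccccc1`: 1.52%

These three compounds were tested in a functional assay on KB cells (Homo sapiens) for inhibition, read by MTT assay, with a stated time of 24 h, tested at 0.1 ug/mL; on this read-out higher numbers stand for more inhibition of growth at the one concentration tested and lower numbers for less inhibition of growth. Compound 3 gives 1.52%, and only compound 1 offers a number to compare it with, at 6.78%. The two numbers lie within the usual scatter of repeated measurements, so they cannot be ranked, and both show little inhibition of growth at the one concentration tested. Compound 2 has no number at all, as it is reported only as "not active" (no number reported).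

The next compound to be measured is compound 4 `O=C(CCCCC(CCSC(=O)c1ccccc1)SC(=O)c1ccccc1)Nc1cccc(Cl)c1`. It keeps the whole of compound 3 except for chloro in place of hydrogen on an aromatic carbon, meta to a large group: chloro in place of hydrogen on an aromatic carbon. Among the measured compounds shown here, no pair of measured compounds differs in just one place, so the effect of such a change cannot be read directly from these data. For the measured compounds named here, the only guide is the low level seen for compound 3 at 1.52% and compound 1 at 6.78%. The estimated change, a number 2.5 percentage points higher from compound 3 to compound 4 (within the scatter), is therefore expected to stay within the scatter, with no clear direction. For compound 4 the expected value is 4%, with an estimated range from 0% to 14%.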

Compound 4, percent growth inhibition at one concentration: 10.7%
Compound 4: middle estimate off by 6.7 percentage points, on the low side, and the stated range covers the measured number.
By their numbers in this assay, from the lowest: compounds 3, 1 and 4 (each within the scatter of the next).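

Among the compounds shown here, this is the first pair here that differs in one place only, so the step of a number 9.2 percentage points higher from compound 3 to compound 4 (within the scatter) in this assay gives a direct reading of chloro in place of hydrogen on an aromatic carbon, meta to a large group. Turning the phenyl of compound 3 into the 3-chlorophenyl of compound 4 therefore gives no difference that can be told apart from ordinary scatter, and both compounds show little inhibition of growth at the one concentration tested. Nothing measured bears on this result, so the data offer no explanation for it.

On these data alone, it remains open whether another group at this same place, such as methoxy or an amine, would give a step beyond the scatter, and whether chloro on a different carbon of the ring would read the same. Because only one concentration is shown, it also remains open whether compound 3 and compound 4 would separate at higher concentrations, where more inhibition of growth might appear.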